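A Fluoromethyl Chain Replaces the Isopropylpropyl Group

This account rests on a few compounds, and the source may have more. Where it says the series, first, only, none or still open, it means among the compounds named here.

The measured compounds:
Compound 1 `COc1cc(C(c2ccc(O)c(OC)c2)[C@@H](C)[C@H](C)CO)ccc1O` gives > 100000 nM in a functional assay on HeLa cells (Homo sapiens) for cytotoxicity, read by WST assay, with a stated time of 48 h (on this read-out higher numbers stand for weaker inhibition and lower numbers for stronger inhibition), which is a limit of the assay and not a number.
Compound 2 `COC[C@H](C(C)C)C(c1ccc(O)c(OC)c1)c1ccc(O)c(OC)c1` gives 76000 nM in this assay.
Compound 3 `CC[C@H](C(C)C)C(c1ccc(O)c(OC)c1)c1ccc(O)c(OC)c1` gives 9700 nM in this assay.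

Compound 3 holds the lowest of the two numbers; its nearest neighbour is compound 2, and the step of a 7.8-fold lower number from compound 2 to compound 3 (0.89 log units; beyond the scatter) lies beyond the scatter. The unmeasured compound 4 `COc1cc(C(c2ccc(O)c(OC)c2)[C@@H](C)[C@@H](C)CF)ccc1O` differs from compound 3 in one place: 2-(fluoromethyl)-1-methylpropyl in place of 1-isopropylpropyl on a saturated chain carbon bound to two aromatic carbons.

Within the data shown here, two measured steps bear on this change. Replacing the 2-(hydroxymethyl)-1-methylpropyl group with 1-isopropylpropyl gave an at least 10-fold lower number from compound 1 to compound 3 (1.01 log units; beyond the scatter), though compound 1 sits only at a limit, and methyl in place of methoxy gave a 7.8-fold lower number from compound 2 to compound 3 (0.89 log units; beyond the scatter). Compound 4 returns toward the shape of compound 1 but carries a 2-(fluoromethyl)-1-methylpropyl group with no hydrogen-bond donor or acceptor, so the expected number is estimated to rise only moderately from compound 3, a 2.1-fold higher number from compound 3 to compound 4 (0.31 log units; beyond the scatter). For compound 4 the estimate in this assay is 20000 nM, expected between 6000 nM and 80000 nM.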

Compound 4, half-maximal inhibitory concentration: 42000 nM
Beside the measured number, compound 4's estimate is 2.1-fold (0.32 log units) below it; measured number inside the range.
By their numbers in this assay, from the lowest: compound 3; then compounds 4 and 2 (each within the scatter of the next). At a limit, above all of these: compound 1.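

Putting 2-(fluoromethyl)-1-methylpropyl in place of 1-isopropylpropyl on this saturated chain carbon gives a 4.3-fold higher number from compound 3 to compound 4 (0.64 log units; beyond the scatter) in this assay, even though neither group has a hydrogen-bond donor or acceptor, while the comparison with the methoxy-bearing chain gives a 1.8-fold lower number from compound 2 to compound 4 (0.26 log units; within the scatter), so those two values cannot be told apart. Putting 1-(fluoromethyl)ethyl in place of 1-(hydroxymethyl)ethyl on a saturated chain carbon bound to two saturated chain carbons gives an at least 2.3-fold lower number from compound 1 to compound 4 (0.37 log units; beyond the scatter). Compound 1 stands at a limit and not a number, so that step is only a floor: the limit of > 100000 nM in this assay, at which 1 of the 4 values shown sits.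

The compounds shown leave open whether the fluorine or the rearranged chain accounts for the rise from compound 3. Going by these compounds, how an amine or a carboxylic acid in place of that fluorine would read in this assay also remains open.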